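Chloro to hydrogen: the next step in the series

A few compounds are considered here, and "the series" means these few. Any claim that something is new, unique, unknown or untested is made for them only; others in the source may bear on it.

Measured so far in a functional assay on the whole organism (strain Swiss) with Mus musculus as the target, in the maximal electroshock model, with a stated time of 1 h, at a dose of 300 mg/kg by the intraperitoneal route; a lower number here means a weaker effect, a higher number a stronger effect of the compound at the dose given:
compound 1 `CCC(C(=O)N1CCN(c2cccc(C)c2)CC1)N1C(=O)CCC1=O`: 75%
compound 2 `CCC(C(=O)N1CCN(c2cccc(Cl)c2)CC1)N1C(=O)CCC1=O`: 100%

Compound 2 stands highest of the two numbers; compound 1 sits beyond the scatter below it, the step being a number 25 percentage points higher from compound 1 to compound 2 (beyond the scatter). Compound 3 `CCC(C(=O)N1CCN(c2ccccc2)CC1)N1C(=O)CCC1=O` is the next one. Its change: hydrogen in place of chloro on an aromatic carbon. Going by the values given here, the only measured step bearing on it is a number 25 percentage points higher from compound 1 to compound 2 (beyond the scatter), for chloro in place of methyl; no step for chloro to hydrogen has been measured. Since compound 2 gives 100%, only a drop is possible in this assay, and a modest one is expected, a number 20 percentage points lower from compound 2 to compound 3 (beyond the scatter). Compound 3 is therefore estimated at 80%, range 55% to 100%.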

Compound 3, a percentage reported as activity, at one dose (the size of the read-out at that dose, not a potency): 75%
The estimate for compound 3 lay 5 percentage points above the measured number, and the stated range covers the measured number.
By their numbers in this assay, from the lowest: compounds 1 and 3 (each within the scatter of the next); then compound 2.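

In this assay, taking chloro off this aromatic carbon lowers the read-out: a number 25 percentage points lower from compound 2 to compound 3 (beyond the scatter). Hydrogen in place of methyl gives no change at the digits printed from compound 1 to compound 3 (within the scatter), so among these three groups only chloro stands apart, and methyl shows no separation from the unsubstituted phenyl. Nothing at hand accounts for this difference.

Open, on these data alone, is whether fluoro, bromo or methoxy at this place would read like chloro or like hydrogen. Also open, as far as these compounds go, is whether the chloro step would hold at a lower dose, or with chloro elsewhere on the ring.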